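Swapping the amine end of the chain for carboxy

The compounds below may be only part of what the source reports. "The series", "measured", "known", "first", "only" and "open" are said of these compounds alone.

For the measured compounds named here, in a physicochemical assay for solubility, read by spectrophotometry, using the shake flask method, with a stated time of 2 days, at pH 6.5 (on this read-out lower numbers stand for lower solubility and higher numbers for higher solubility), compound 1 `O=C(O)CCCOc1ccc2nc(-c3cn(-c4ccc(O)c(F)c4)nn3)ccc2c1` gives 19.2 ug/mL and compound 2 `NCCOCCOc1ccc2nc(-c3cn(-c4ccc(O)c(F)c4)nn3)ccc2c1` gives 9.1 ug/mL, the lower of the two numbers so far. The next compound is compound 3 `O=C(O)COCCOc1ccc2nc(-c3cn(-c4ccc(O)c(F)c4)nn3)ccc2c1`, which keeps the chain of compound 2 and changes only its end: carboxy in place of aminomethyl on a saturated chain carbon bound to an oxygen on a saturated carbon. In words, this is carboxy in place of aminomethyl on a saturated chain carbon bound to an oxygen on a saturated carbon.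

Going by the values given here, only one measured step bears on this change: a 2.1-fold lower number from compound 1 to compound 2 (0.32 log units; beyond the scatter). It is modest, and it replaces carboxymethyl with 2-aminoethoxy on a saturated chain carbon, two bonds along the chain from an oxygen on an aromatic ring. The change to compound 3 runs the other way, from an amine end to a carboxy end, so a rise of similar modest size is expected in this assay. The chains of compound 1 and compound 3 differ, however, and a single step gives thin support, so the range stays wide.

The expected change is a 2.0-fold higher number from compound 2 to compound 3 (0.30 log units; within the scatter). For compound 3 the estimated value is 18 ug/mL, with an expected range of 8 ug/mL to 42 ug/mL.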

Compound 3, solubility: 867 ug/mL
Estimate against measurement, compound 3: 48-fold (1.68 log units) below, and the stated range ends below it.
By their numbers in this assay, from the lowest: compound 2; then compound 1; then compound 3.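

In this assay, for the compounds shown here, the end of this chain matters far more than the earlier compounds suggested: carboxy in place of aminomethyl gives a 95-fold higher number from compound 2 to compound 3 (1.98 log units; beyond the scatter), a large step where the only earlier step was modest. A carboxy end does not by itself give the high number, as compound 1 also carries one, and carboxymethoxy in place of carboxymethyl gives a 45-fold higher number from compound 1 to compound 3 (1.65 log units; beyond the scatter), so the two large steps point to the combination of chain and end found in compound 3. Nothing available here accounts for the size of either step.

Still open, going by these compounds, is whether the high number depends on the free carboxylic acid, which a methyl ester or a primary amide at the same chain end would test, and whether a neutral hydroxy end on this chain stays nearer compound 2 or compound 3. Also open, on these data alone, is how far the result holds with a longer chain carrying the carboxymethoxy end, or with a second ether oxygen in that chain.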